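This account rests on a few compounds, and the source may have more. Where it says the series, first, only, none or still open, it means among the compounds named here.

For the measured compounds named here, in an ADME assay on L6 cells (Rattus norvegicus) for cytotoxicity (on this read-out higher numbers stand for weaker inhibition and lower numbers for stronger inhibition), two compounds sharing one core have numbers so far. Compound 1 `C/C=C(/C)C(=O)OC(C)c1cc2c(cc1OC)OC(C)(C)C=C2` gives 139000 nM, while compound 2 `COc1cc2c(cc1C(C)NCCCc1ccccc1)C=CC(C)(C)O2` gives 1080 nM. Compound 2 therefore holds the lower of the two numbers, meaning stronger inhibition of the cells, and the gap between them lies well beyond the usual scatter of repeat measurements.

Compound 3 `COc1ccc(CNC(C)c2cc3c(cc2OC)OC(C)(C)C=C3)cc1` has not yet been measured. Compared with compound 2, it carries 4-methoxyphenyl in place of phenethyl on a saturated chain carbon bound to an amine nitrogen. Going by the values given here, no measured pair shows what this swap does, so the expectation is anchored only on compound 2 at 1080 nM and remains uncertain. A modest rise toward weaker inhibition is expected, with the estimated step of a 3.7-fold higher number from compound 2 to compound 3 (0.57 log units; beyond the scatter) in this assay. For compound 3, the estimated value is 4000 nM, with an expected range from 1200 nM to 15000 nM.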

Compound 3, half-maximal inhibitory concentration: 14900 nM
Compound 3: the middle estimate sits 3.7-fold (0.57 log units) below what was measured, within the range that was stated.
By their numbers in this assay, from the lowest: compound 2; then compound 3; then compound 1.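

Replacing phenethyl with 4-methoxyphenyl on a saturated chain carbon bound to an amine nitrogen gives a 14-fold higher number from compound 2 to compound 3 (1.14 log units; beyond the scatter) in this assay, so the group at this position strongly affects the read-out. The change means weaker inhibition of the cells, even though both groups have the same number of heavy atoms and one six-membered aromatic ring each. The entering group does add one hydrogen-bond acceptor, but no measurement here links that difference, or any other, to the step.

The swap changes more than one feature at once, so the compounds shown cannot separate the contribution of the methoxy group from that of the remaining change. A plain phenyl group at this place would help to divide the two, while a longer chain ending in 4-methoxyphenyl would show whether the methoxy group is tolerated further out.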